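This account rests on a few compounds, and the source may have more. Where it says the series, first, only, none or still open, it means among the compounds named here.

Measured compounds:
- Compound 1 `CC(C)Oc1ccc(N2C[C@@H](C)N[C@@H](C)C2)cc1NS(=O)(=O)c1ccc(-c2ccccn2)s1` in a functional assay for agonist activity at growth hormone secretagogue receptor type 1 (Homo sapiens), read by FLIPR (a higher number here means a larger maximal response, a lower number a smaller maximal response), gives 1.1.
- Compound 2 `COc1ccc(F)c(-c2ccc(S(=O)(=O)Nc3cc(N4C[C@@H](C)N[C@@H](C)C4)ccc3OC)cc2)c1` gives 1.2.
- Compound 3 `COc1cccc(-c2ccc(S(=O)(=O)Nc3cc(N4C[C@@H](C)N[C@@H](C)C4)ccc3OC)cc2)c1` gives 1.

Compound 3 has the lowest of these three numbers. Its gap to compound 1 lies within the scatter, so the two cannot be told apart, whereas the step a number 0.20 lower from compound 2 to compound 3 (beyond the scatter) does lie beyond it. Compound 4 `COc1ccc(N2C[C@@H](C)N[C@@H](C)C2)cc1NS(=O)(=O)c1ccc(N2CCCC2=O)cc1` differs from compound 3 in one place: 2-oxopyrrolidin-1-yl in place of 3-methoxyphenyl on an aromatic carbon.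

Among the compounds with values here, only one measured step is available, a number 0.20 lower from compound 2 to compound 3 (beyond the scatter), and it concerns a fluoro replaced by hydrogen on the 3-methoxyphenyl group, not the replacement of that whole group by 2-oxopyrrolidin-1-yl. It therefore gives no direct guide. What the three numbers do show is that all of them sit close to the largest response of the reference agonist, and compound 3 is part of that cluster. With no measured change of this kind, the plainest expectation is that compound 4 stays in the same region, with no step beyond the scatter in either direction.

The expected value for compound 4 is 1, in a range from 0.8 to 1.2. This estimate means an expected step of no change at the digits printed from compound 3 to compound 4 (within the scatter), which lies within the scatter.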

Compound 4, intrinsic activity: the largest response reached, as a fraction of the reference agonist's: 0.8
For compound 4 the middle estimate is 0.20 above the measured one, within the range that was stated.
By their numbers in this assay, from the lowest: compound 4; then compounds 3, 1 and 2 (each within the scatter of the next, the first and the last beyond it).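

In this assay, the group on this aromatic carbon, para to a large group, proves able to move the maximal response: putting 2-oxopyrrolidin-1-yl in place of 3-methoxyphenyl gives a number 0.20 lower from compound 3 to compound 4 (beyond the scatter). Set against the fluorinated aromatic group, the same kind of replacement gives a larger step, a number 0.40 lower from compound 2 to compound 4 (beyond the scatter), so the earlier fluoro-to-hydrogen step was not the only change here to reach beyond the scatter. Nothing available explains why the response falls with this change.

The swap alters ring size, aromatic character and the presence of a ring nitrogen and carbonyl all at once, so the compounds shown cannot separate these features. As far as these compounds go, how a plain phenyl group or a morpholin-4-yl group would behave on this carbon also stays open.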